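The source may report more compounds than this note shows. Statements on the series, on what has been measured and on what is new or still open speak of the compounds shown alone.

Compound 1 `COc1cc(/C=C/C(=O)c2sc(Nc3ccc(C)cc3)nc2C)cc(OC)c1OC` belongs to a small set of three measured compounds that share one core and differ in the substituents around it. In a functional assay on PC-3 cells (Homo sapiens) for cytotoxicity, read by MTT assay (a lower number here means a stronger inhibitor, a higher number a weaker inhibitor), compound 1 gives > 25000 nM, which is a limit of the assay rather than a number. Compound 2 `Cc1cccc(Nc2nc(C)c(C(=O)/C=C/c3ccccc3Cl)s2)c1` gives 22200 nM in this assay. Compound 3 `Cc1ccccc1Nc1nc(C)c(C(=O)/C=C/c2ccc(Cl)cc2)s1` gives > 25000 nM, again a limit. So compound 1 stands at the limit of > 25000 nM in this assay, at which 2 of the 3 values shown sit, and none of the three reaches a clearly measurable potency. Compound 4 `COc1cc(/C=C/C(=O)c2sc(Nc3cccc(C)c3)nc2C)cc(OC)c1OC` is not yet measured; it differs from compound 1 by 3-methylphenyl in place of 4-methylphenyl on a nitrogen on an aromatic ring. Going by the values given here, no pair of measured compounds isolates this change, so the step is expected to be none beyond the scatter. Compound 4 is therefore estimated at 30000 nM, between 15000 nM and 60000 nM, a step that the limit leaves unreadable from compound 1 to compound 4.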

Compound 4, half-maximal inhibitory concentration: > 25000 nM
Compound 4 gave a limit, no number (the forecaster's own chance of this, stated with the estimate: 70%); the middle value lies beyond the limit too.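

Compound 1 and compound 4 both give only a limit, so no step can be read between them, and the evidence is: the limit of > 25000 nM in this assay, at which 3 of the 4 values shown sit.

The compounds shown leave open whether 3-methylphenyl and 4-methylphenyl differ at all in this assay.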